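Methyl on the chain carbon: same change, new core

The compounds below may be only part of what the source reports. "The series", "measured", "known", "first", "only" and "open" are said of these compounds alone.

Measured so far:
Compound 1, `CC(=O)N(C)C(C)C#CCn1ccnc1`, gives 2 mg/kg.
Compound 2, `CC(=O)N(C)CC#CCn1ccnc1`, gives 0.97 mg/kg.
Compound 3, `COC(=O)N(C)CC#CCN1CCCC1`, gives 1.4 mg/kg.

These values come from a functional assay on the whole organism for agonist activity, with Mus musculus as the target; a lower number here means that less compound is needed, a higher number that more compound is needed for the effect. Going from compound 2 to compound 1, the change is methyl in place of hydrogen on a saturated chain carbon bound to an amide-type nitrogen and a triple-bonded carbon, and the step is a 2.1-fold higher number from compound 2 to compound 1 (0.31 log units; beyond the scatter). Compound 3 carries a different core than compound 2; the difference between the two cores is not broken down here. Compound 4, `COC(=O)N(C)C(C)C#CCN1CCCC1`, has not yet been measured. It differs from compound 3 by methyl in place of hydrogen on a saturated chain carbon bound to an amide-type nitrogen and a triple-bonded carbon, the same change as between compound 2 and compound 1. Because the earlier step was a 2.1-fold higher number from compound 2 to compound 1 (0.31 log units; beyond the scatter), a similar rise in the dose is expected here, so the expected step is a 2.1-fold higher number from compound 3 to compound 4 (0.32 log units; beyond the scatter). Compound 4 is therefore estimated at 2.9 mg/kg, likely between 1.5 mg/kg and 6 mg/kg.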

Compound 4, dose for half-maximal effect: 9.7 mg/kg
Beside the measured number, compound 4's estimate is 3.3-fold (0.52 log units) below it; measured number outside the range, above it.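

Methyl in place of hydrogen on this chain carbon gives a 6.9-fold higher number from compound 3 to compound 4 (0.84 log units; beyond the scatter) in this assay and so points the same way as a 2.1-fold higher number from compound 2 to compound 1 (0.31 log units; beyond the scatter) on the other core. The direction carries over from one core to the other, but the size does not: the same change on two cores in this assay, a 2.1-fold higher number (0.31 log units; beyond the scatter) from compound 2 to compound 1 and a 6.9-fold higher number (0.84 log units; beyond the scatter) from compound 3 to compound 4, 3.4-fold (0.53 log units) apart, beyond the scatter of two such steps
Two cores show only that the direction held in these two cases; they do not show which part of the cores sets the size of the step, or how a third core would respond.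

From the compounds shown here alone, whether ethyl or a longer chain on that same carbon would raise the number further stays open. So does whether a hydroxyl group there would behave like methyl.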